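Second chloro on the aryl ring of compound 2

This account rests on a few compounds, and the source may have more. Where it says the series, first, only, none or still open, it means among the compounds named here.

Measured compounds:
compound 1 `O=c1c2ccc(F)cc2ccn1[C@@H]1O[C@H](COP(=O)(O)OP(=O)(O)OP(=O)(O)O)[C@@H](O)[C@H]1O` 77 nM
compound 2 `O=c1c2ccc(Cl)cc2ccn1[C@@H]1O[C@H](COP(=O)(O)OP(=O)(O)OP(=O)(O)O)[C@@H](O)[C@H]1O` 541 nM
compound 3 `N#Cc1ccc2c(=O)n([C@@H]3O[C@H](COP(=O)(O)OP(=O)(O)OP(=O)(O)O)[C@@H](O)[C@H]3O)ccc2c1` 88 nM

In a functional assay for agonist activity at P2Y purinoceptor 2 (Homo sapiens), read by FLIPR (a higher number here means that more compound is needed for the effect, a lower number that less compound is needed), compound 2 stands highest of the three numbers shown. Its nearest neighbour is compound 3, at a 6.1-fold lower number from compound 2 to compound 3 (0.79 log units; beyond the scatter); the other step, a 7.0-fold higher number from compound 1 to compound 2 (0.85 log units; beyond the scatter), is of similar size. Compound 1 and compound 3 lie within the scatter of each other, so no order between them can be read.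

Compound 4 `O=c1c2cc(Cl)c(Cl)cc2ccn1[C@@H]1O[C@H](COP(=O)(O)OP(=O)(O)OP(=O)(O)O)[C@@H](O)[C@H]1O` keeps the chloro of compound 2 and adds a second one: chloro in place of hydrogen on an aromatic carbon. For the measured compounds named here, none of the measured steps bears directly on this change; each of them swaps one group for another at a single position, whereas here a hydrogen on an aromatic carbon ortho to a chloro group is replaced while the first chloro stays. The steps involving compound 2 show that the swap at this ring is felt beyond the scatter, but they give no direction for an added chloro at a new position. Going by the values given here, with no bearing step, the expectation for compound 4 in this assay is a number near that of compound 2, with wide uncertainty: a 1.3-fold higher number from compound 2 to compound 4 (0.11 log units; within the scatter) is the step expected, and compound 4 is estimated at 700 nM within 200 nM to 2500 nM.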

Compound 4, half-maximal effective concentration: 13 nM
Estimate against measurement, compound 4: 54-fold (1.73 log units) above; the measured number lies below the stated range.
By their numbers in this assay, from the lowest: compound 4; then compounds 1 and 3 (each within the scatter of the next); then compound 2.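

In this assay, a chloro on the aromatic carbon ortho to the chloro group of compound 2 gives a 42-fold lower number from compound 2 to compound 4 (1.62 log units; beyond the scatter), a large step, whereas the swaps among fluoro, chloro and cyano in compounds 1 to 3 were modest at most. This carbon, which carries hydrogen in compounds 1 to 3, therefore matters strongly in this assay, and an added chloro here takes the number in the opposite direction to that assumed from compound 2 alone. Nothing measured here accounts for the size of this step.

It remains open whether the new chloro needs the existing one, since no compound shown carries it alone or pairs it with fluoro or cyano. Whether a methyl, a methoxy or an amine at this carbon would give a similar step is also unresolved.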